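The source may report more compounds than this note shows. Statements on the series, on what has been measured and on what is new or still open speak of the compounds shown alone.

In a toxicity assay on NIH3T3 cells (Mus musculus) for cytotoxicity, read by resazurin assay (a higher number here means that more compound is needed for the effect, a lower number that less compound is needed), compound 1 (`c1ccc(-c2ccc(Cn3cncc3CNc3ccc(-c4nc5ccccc5s4)c(-c4ccccc4)c3)cc2)cc1`) gives > 1000 nM, a limit and not a number. Compound 2 (`CN(C)C(=O)c1ccc(NCc2cncn2Cc2ccc(-c3ccccc3)cc2)cc1-c1ccccc1`) gives > 1000 nM, likewise only a limit. Among the measured compounds shown here, the one measured step is a step that the two limits leave unreadable from compound 1 to compound 2, with dimethylcarbamoyl in place of 1,3-benzothiazol-2-yl on an aromatic carbon. Compound 3 (`c1ccc(-c2ccc(Cn3cncc3CNc3ccc(-c4onc5ccccc45)c(-c4ccccc4)c3)cc2)cc1`) differs from compound 2 by a group of 9 heavy atoms (7 carbon, 1 nitrogen, 1 oxygen; one five-membered aromatic ring with 2 hetero atoms, one six-membered aromatic ring of carbon only) in place of a group of 5 heavy atoms (3 carbon, 1 nitrogen, 1 oxygen; no ring), on an aromatic carbon, the new group standing ortho to a phenyl group. For the measured compounds named here, the only guide is the limit of > 1000 nM in this assay, at which 2 of the 2 values shown sit, which gives no readable step size. Compound 3 carries a group with two fused aromatic rings, as compound 1 does with its 1,3-benzothiazol-2-yl, and compound 1 gives > 1000 nM as its limit. No step beyond the scatter is therefore expected in this assay, and no direction can be given. The estimated step is a step that the limit leaves unreadable from compound 2 to compound 3 in this expectation. Compound 3 is expected near 2000 nM, with an estimated range from 700 nM to 6000 nM here.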

Compound 3, half-maximal effective concentration: > 10000 nM
Compound 3: no number, only a limit; the forecaster's own chance of this, stated with the estimate: 80%; middle value at least 5.0-fold (0.69 log units) from the limit.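

Compound 3 gives > 10000 nM, a limit and not a number. Among the compounds shown here, compound 1 and compound 2 are also known only as limits, so no step among the three can be read. The compounds shown leave open whether these groups on the aromatic carbon differ at all in this assay.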